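A Dimethylphenyl Isomer Awaits Its Measurement

The source may hold more compounds than are shown below. What is called first, only, known or untested is meant among the compounds shown, and "the series" means these compounds.

In a functional assay on HepG2 cells (Homo sapiens) for antiproliferative activity, read by MTT assay, with a stated time of 48 h (a higher number here means a weaker inhibitor, a lower number a stronger inhibitor), compound 1 `COc1ccc(/C=C/c2cc(OC)cc(OC)c2/C=C/C(=O)c2cccc(Br)c2)cc1` gives 13 ug/mL while compound 2 `COc1ccc(/C=C/c2cc(OC)cc(OC)c2/C=C/C(=O)c2ccc(C)cc2C)cc1` gives 0.9 ug/mL and so holds the lower of the two numbers, which marks the stronger inhibitor of this pair. Among the compounds with values here, the only measured step is a 14-fold lower number from compound 1 to compound 2 (1.16 log units; beyond the scatter) and it came from putting 2,4-dimethylphenyl in place of 3-bromophenyl on a carbonyl carbon. Compound 3 `COc1ccc(/C=C/c2cc(OC)cc(OC)c2/C=C/C(=O)c2ccc(C)c(C)c2)cc1` keeps the shared core and differs from compound 2 by 3,4-dimethylphenyl in place of 2,4-dimethylphenyl on a carbonyl carbon on that same carbonyl carbon, with the same atoms joined differently. The measured step bears on this change only loosely. Within the data shown here, it shows that swapping the group at this place can move the number a long way, but no measured pair isolates a shift of one methyl group. Compound 2 at 0.9 ug/mL is also the lower of just two numbers, so a further fall seems less likely than a modest rise. The expected change is a 2.8-fold higher number from compound 2 to compound 3 (0.44 log units; beyond the scatter) and it carries wide uncertainty. Compound 3 is expected at 2.5 ug/mL with an estimated range from 0.7 ug/mL to 9 ug/mL until it is measured.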

Compound 3, half-maximal inhibitory concentration: 0.2 ug/mL
Beside the measured number, compound 3's estimate is 13-fold (1.10 log units) above it; measured number below the stated range.
By their numbers in this assay, from the lowest: compound 3; then compound 2; then compound 1.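

In this assay, 3,4-dimethylphenyl in place of 2,4-dimethylphenyl on the carbonyl carbon gives a 4.5-fold lower number from compound 2 to compound 3 (0.65 log units; beyond the scatter), even though the two groups have the same atoms and the same counts of rings, donors and acceptors, so the way the atoms are joined at this place is enough to shift the number beyond the scatter. The step with 3,4-dimethylphenyl in place of 3-bromophenyl is larger, a 65-fold lower number from compound 1 to compound 3 (1.81 log units; beyond the scatter), and it leaves compound 3 with the lowest number of the three, its steps to both other compounds being beyond the scatter. Nothing available here accounts for either step.

With only two dimethylphenyl arrangements shown, it remains open whether both methyl groups are needed or whether one alone would give a similarly low number. On these data alone, it is also open how the number would respond if an ethyl group, an amine or a carboxylic acid stood on the ring at this place instead of the methyl groups.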